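The compounds below may be only part of what the source reports. "The series", "measured", "known", "first", "only" and "open" are said of these compounds alone.

Working notes on the series. Compound 1 `COc1c(Cl)cccc1-n1c(C)cc(C(=O)O)c1C` gives 800 nM in an assay on cells for inhibition of Palmitoleoyl-protein carboxylesterase NOTUM variant C330S (Homo sapiens), read by fluorescence, with a stated time of 40 min; on this read-out lower numbers stand for stronger inhibition and higher numbers for weaker inhibition. Compound 2 `Cc1cc(C(=O)O)c(C)n1-c1cccc(Cl)c1` gives 430 nM in this assay and sits at the low end of the two numbers seen so far, though its gap to compound 1 lies within the scatter; that step, a 1.9-fold lower number from compound 1 to compound 2 (0.27 log units; within the scatter), brings hydrogen in place of methoxy on an aromatic carbon. Compound 3 `Cc1cc(C(=O)O)c(C)n1-c1cccc(Cl)c1F` carries fluoro in place of hydrogen on an aromatic carbon. Within the data shown here, no measured step introduces a second halogen on this ring, and the one step seen stayed within scatter, so no shift beyond scatter is expected. Compound 3 is expected at 400 nM, range 150 nM to 1200 nM, an estimated step of a 1.1-fold lower number from compound 2 to compound 3 (0.03 log units; within the scatter).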

Compound 3, half-maximal inhibitory concentration: 380 nM
Estimate against measurement, compound 3: 1.1-fold (0.02 log units) above, and the stated range covers the measured number.
By their numbers in this assay, from the lowest: compounds 3, 2 and 1 (each within the scatter of the next, the first and the last beyond it).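

In this assay, the aromatic carbon ortho to a chloro group takes fluoro in place of hydrogen with no shift beyond the scatter (a 1.1-fold lower number from compound 2 to compound 3 (0.05 log units; within the scatter)). Against methoxy at that carbon, fluoro gives the first step in the series beyond the scatter, though a modest one (a 2.1-fold lower number from compound 1 to compound 3 (0.32 log units; beyond the scatter)). (Nothing available explains either step)

Still open, going by these compounds, is how an amine, a hydroxyl group or a longer chain would read at this carbon. Also open, on these data alone, is whether the fluoro step would hold without the chloro group.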